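The source may hold more compounds than are shown below. What is called first, only, known or untested is meant among the compounds shown, and "the series" means these compounds.

Measured in an ADME assay on MOLT-3 cells (Homo sapiens) for cytotoxicity, with a stated time of 7 days; a higher number here means that more compound is tolerated, a lower number that less compound is tolerated:
- Compound 1 `C=CCOc1nc(N)nc2c1ncn2/C=C1/CC1(CO)CO`: > 20000 nM, a limit
- Compound 2 `COCCOc1nc(N)nc2c1ncn2/C=C1/CC1(CO)CO`: > 20000 nM, a limit

Compound 2 stands at > 20000 nM, which is a limit and not a number. Both measured compounds share this position: the limit of > 20000 nM in this assay, at which 2 of the 2 values shown sit. Compound 3 `CCCCCCCCOc1nc(N)nc2c1ncn2/C=C1/CC1(CO)CO` has hexyl in place of methoxy on a saturated chain carbon, two bonds along the chain from an oxygen on an aromatic ring. Among the measured compounds shown here, the only measured step, a step that the two limits leave unreadable from compound 1 to compound 2, offers no size to carry over. In this assay, only a modest, uncertain fall is therefore expected, and another limit is quite possible. The expected change is an at least 1.3-fold lower number from compound 2 to compound 3 (0.12 log units; that floor lies within the scatter). For compound 3, the estimate is 15000 nM, with an expected range of 4000 nM to 30000 nM.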

Compound 3, half-maximal cytotoxic concentration: > 20000 nM
Compound 3: only a limit was reported; the forecaster's own chance of this, stated with the estimate: 55%; middle value at least 1.3-fold (0.12 log units) away from the limit.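

Among the compounds shown here, compound 3, like compound 1 and compound 2, gives only a limit and not a number, so no step among them can be read: the limit of > 20000 nM in this assay, at which 3 of the 3 values shown sit. Going by these compounds, what stays open is how the three truly compare in this assay, and whether the side chain changes tolerance at all.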